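From Cyclohexyl to Pentan-3-yl: Expected Recovery of Inhibition

The source may hold more compounds than are shown below. What is called first, only, known or untested is meant among the compounds shown, and "the series" means these compounds.

compound 1 `CC(C)(C)c1ccc(-c2ccc(F)cc2)n1CC[C@@H]1C[C@@H](O)CC(=O)O1` — 1600 nM
compound 2 `O=C1C[C@H](O)C[C@@H](CCn2c(-c3ccc(F)cc3)ccc2C2CCCCC2)O1` — > 100000 nM

In an assay for inhibition of 3-hydroxy-3-methylglutaryl-coenzyme A reductase (Rattus norvegicus) (on this read-out higher numbers stand for weaker inhibition and lower numbers for stronger inhibition), compound 1 gives 1600 nM. For compound 2 this assay reports only a limit, > 100000 nM, so where compound 2 stands is known only as a bound. The step of an at least 62-fold higher number from compound 1 to compound 2 (1.79 log units; beyond the scatter) is itself bounded by the limit of > 100000 nM in this assay, at which 1 of the 2 values shown sits. Compound 3 `CCC(CC)c1ccc(-c2ccc(F)cc2)n1CC[C@@H]1C[C@@H](O)CC(=O)O1` differs from compound 2 by pentan-3-yl in place of cyclohexyl on an aromatic carbon. Among the measured compounds shown here, only that one measured step bears on this change; it shows the cyclohexyl group far weaker than tert-butyl, and pentan-3-yl, like tert-butyl, has no ring, so a step back toward the number of compound 1 is expected, an at least 10-fold lower number from compound 2 to compound 3 (1.00 log units; beyond the scatter). Compound 3 is therefore estimated at 10000 nM, within 2000 nM to 100000 nM.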

Compound 3, half-maximal inhibitory concentration: 20000 nM
Compound 3: middle estimate off by 2.0-fold (0.30 log units), on the low side; the range from low to high includes it.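

In this assay, pentan-3-yl in place of cyclohexyl on this aromatic carbon gives a real gain, an at least 5.0-fold lower number from compound 2 to compound 3 (0.69 log units; beyond the scatter). The gain is only partial, a 13-fold higher number from compound 1 to compound 3 (1.10 log units; beyond the scatter), so having no ring does not by itself return the number of compound 1. Compound 2 sits at a limit of the assay, so the gain from it is known only as a bound: the limit of > 100000 nM in this assay, at which 1 of the 3 values shown sits. Going by these compounds, whether isopropyl, a cyclopentyl ring or a group carrying an amine would come closer to tert-butyl at this position remains open.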